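Furan to thiophene swap on a carbamoyl core

A few compounds are considered here, and "the series" means these few. Any claim that something is new, unique, unknown or untested is made for them only; others in the source may bear on it.

Compound 1 `CCCOC(=O)C1=C(C)NC(=O)NC1c1ccoc1` and compound 2 `CCCOC(=O)C1=C(C)NC(=O)NC1c1ccsc1` share one core, and compound 3 `CC1=C(C(N)=O)C(c2ccoc2)NC(=O)N1` and compound 4 `CC1=C(C(N)=O)C(c2ccsc2)NC(=O)N1` share another. In an assay on membranes from CHO cells for displacement of a labelled ligand from adenosine receptor A1 (Homo sapiens), read by scintillation counting, with a stated time of 60 min, tested at 1 uM (on this read-out lower numbers stand for less inhibition and higher numbers for more inhibition at the one concentration tested (going by the name of the read-out)), compound 1 gives 50%, compound 2 gives 44% and compound 3 gives 1%. Between compound 1 and compound 2 the change is thiophen-3-yl in place of furan-3-yl on a saturated ring carbon, and it made a step of a number 6 percentage points lower from compound 1 to compound 2 (within the scatter). The two cores differ by amino in place of propoxy on a carbonyl carbon, with a step of a number 49 percentage points lower from compound 1 to compound 3 (beyond the scatter) in this assay. The change from compound 3 to compound 4 is thiophen-3-yl in place of furan-3-yl on a saturated ring carbon: the same kind of change as before, but not the same, since in the first pair the altered carbon is next to the ring atom that bears a propoxycarbonyl group, whereas in the second pair it is next to the ring atom that bears a carbamoyl group. The step from compound 3 to compound 4 is expected to be a number 2 percentage points higher from compound 3 to compound 4 (within the scatter), about as small as the first one, because the earlier swap gave a number 6 percentage points lower from compound 1 to compound 2 (within the scatter). Compound 4 is therefore estimated at 3%, likely between 0% and 15%.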

Compound 4, a percentage reported as inhibition, at one concentration (the size of the read-out at that concentration, not a potency): 2%
Beside the measured number, compound 4's estimate is 1 percentage points above it, and the stated range covers the measured number.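

In this assay, thiophen-3-yl in place of furan-3-yl gave a step of a number 1 percentage points higher from compound 3 to compound 4 (within the scatter), so this swap behaves alike on both cores: the same change on two cores in this assay, a number 6 percentage points lower (within the scatter) from compound 1 to compound 2 and a number 1 percentage points higher (within the scatter) from compound 3 to compound 4, 7 percentage points apart, within the scatter of two such steps. Amino in place of propoxy on a carbonyl carbon gave a step of a number 42 percentage points lower from compound 2 to compound 4 (beyond the scatter), and this large loss also carries over from the furan-3-yl pair to the thiophen-3-yl pair: the same change on two cores in this assay, a number 49 percentage points lower (beyond the scatter) from compound 1 to compound 3 and a number 42 percentage points lower (beyond the scatter) from compound 2 to compound 4, 7 percentage points apart, within the scatter of two such steps. Among the compounds shown here, this agreement rests on only two pairs for each change, and the swap result is a weak test, since compound 3 at 1% and compound 4 at 2% sit so close to the bottom of the scale that a further fall would have little room to show.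

The compounds shown leave open how the read-out responds to other groups on the carbonyl carbon, such as an ethoxy or a methylamino group. They also leave open whether a phenyl ring on the saturated ring carbon would fit the pattern seen with furan-3-yl and thiophen-3-yl.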